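Series notes: trifluoromethyl benzyl variant of compound 2

A few compounds are considered here, and "the series" means these few. Any claim that something is new, unique, unknown or untested is made for them only; others in the source may bear on it.

Compound 2 `COc1ccc(F)cc1CNCCCNc1ccnc2cc(Cc3ccc(F)cc3Cl)ccc12` gives 4200 nM in a physicochemical assay for solubility, with a stated time of 18 h, at pH 7.4; on this read-out lower numbers stand for lower solubility and higher numbers for higher solubility. Compound 1 `Fc1ccc(Cc2ccc3c(NCCCNCc4ccco4)ccnc3c2)c(Cl)c1` gives 4200 nM and compound 3 `COc1cccc(CNCCCNc2ccnc3cc(Cc4ccc(F)cc4Cl)ccc23)c1O` gives 4200 nM, so compound 2 stands level with both at the digits shown; no change at the digits printed from compound 1 to compound 2 (within the scatter), no change at the digits printed from compound 1 to compound 3 (within the scatter) and no change at the digits printed from compound 2 to compound 3 (within the scatter) all lie within the scatter. Compound 4 `COc1ccc(F)cc1CNCCCNc1ccnc2cc(Cc3cccc(C(F)(F)F)c3)ccc12` carries 3-(trifluoromethyl)phenyl in place of 2-chloro-4-fluorophenyl on a saturated chain carbon bound to an aromatic carbon. Going by the values given here, every measured step varies the group on a saturated chain carbon bound to an amine nitrogen; none varies the group on a saturated chain carbon bound to an aromatic carbon, so no measured step bears directly on this change. The three measured compounds sit at one figure. For compound 4 the step of no change at the digits printed from compound 2 to compound 4 (within the scatter) is expected to stay within the scatter. Compound 4 is estimated at 4200 nM, with a range of 1500 nM to 12000 nM.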

Compound 4, solubility: 4200 nM
Estimate against measurement, compound 4: no gap at the digits printed; the measured number falls inside the stated range.
By their numbers in this assay, from the lowest: compounds 1, 2, 3 and 4 (each within the scatter of the next).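

In this assay there is no change at the digits printed from compound 2 to compound 4 (within the scatter) for the first change shown on a saturated chain carbon bound to an aromatic carbon, 3-(trifluoromethyl)phenyl in place of 2-chloro-4-fluorophenyl. The figure therefore holds at this position as well as on a saturated chain carbon bound to an amine nitrogen. No measurement on hand accounts for this result.

Still open, on these data alone, is whether the figure holds with a group carrying an amine or a carboxylic acid on a saturated chain carbon bound to an aromatic carbon. A longer chain between the two nitrogens of these compounds also remains to be read.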